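The source may report more compounds than this note shows. Statements on the series, on what has been measured and on what is new or still open speak of the compounds shown alone.

Measured in a functional assay on A549 cells (Homo sapiens) for antiproliferative activity, read by MTT assay, with a stated time of 24 h; on this read-out higher numbers stand for weaker inhibition and lower numbers for stronger inhibition:
- compound 1 `Cc1ccccc1NNC(=O)c1ccccc1NS(=O)(=O)c1cnc(O)nc1O`: > 20000 nM (a limit)
- compound 2 `Cc1cccc(NNC(=O)c2ccccc2NS(=O)(=O)c2cnc(O)nc2O)c1`: > 20000 nM (a limit)
- compound 3 `CCCCOc1ccc(C(=O)NNC(=O)c2ccccc2NS(=O)(=O)c2cnc(O)nc2O)cc1`: 4960 nM

Compound 3 is the only one of the three with an actual number. The other two sit at the limit of > 20000 nM in this assay, at which 2 of the 3 values shown sit.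

Compound 4 `Cc1ccc(C(=O)NNC(=O)c2ccccc2NS(=O)(=O)c2cnc(O)nc2O)cc1` has methyl in place of butoxy on an aromatic carbon, para to a large group: methyl in place of butoxy on an aromatic carbon.

Among the compounds with values here, the one measured step, a step that the two limits leave unreadable from compound 1 to compound 2, concerns a different change and has no readable size, so no measured step sizes this one. Within the data shown here, the expected direction in this assay is towards weaker inhibition, a cautious guess resting on compound 3, at 4960 nM, being the only measured compound with butoxy and the only one with a number. The expected change is a 2.0-fold higher number from compound 3 to compound 4 (0.30 log units; within the scatter). Compound 4 is estimated at 10000 nM, with an expected range of 4000 nM to 25000 nM.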

Compound 4, half-maximal inhibitory concentration: > 20000 nM
Compound 4 was reported as a limit; the forecaster's own chance of this, stated with the estimate: 40%; middle value at least 2.0-fold (0.30 log units) from the limit.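

Cutting butoxy back to methyl on this aromatic carbon, para to a large group, gives in this assay an at least 4.0-fold higher number from compound 3 to compound 4 (0.60 log units; beyond the scatter), the first readable size for a change at this place. Compound 4 gives > 20000 nM, which is a limit and not a number. The steps joining compound 4 to compound 1 and compound 2 cannot be read: the limit of > 20000 nM in this assay, at which 3 of the 4 values shown sit.

As far as these compounds go, how much activity is truly lost remains open, as the true size of the step is unknown. A methoxy, pentyl or hexyloxy group here would help show whether the chain length or the oxygen matters.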